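Chain-Lengthened Iodoacetamide Nucleotides Tested Against Hexokinase-2

The compounds below may be only part of what the source reports. "The series", "measured", "known", "first", "only" and "open" are said of these compounds alone.

Three iodoacetamide-bearing nucleotide analogues have been measured. Compound 3 `Nc1ncnc2c1nc(NCCNC(=O)CI)n2[C@@H]1O[C@H](COP(=O)(O)OP(=O)(O)OP(=O)(O)O)[C@@H](O)[C@H]1O` gives 0% in an assay on isolated protein for inhibition of hexokinase-2 (Rattus norvegicus), with a stated time of 6 h, tested at 10 mM; a higher number here means more inhibition at the concentration tested (going by the name of the read-out), a lower number less inhibition. Compound 1 `Nc1ncnc2c1nc(NCCCCNC(=O)CI)n2[C@@H]1O[C@H](COP(=O)(O)OP(=O)(O)OP(=O)(O)O)[C@@H](O)[C@H]1O` differs from compound 3 by 2-(((iodomethyl)carbonyl)amino)ethyl in place of ((iodomethyl)carbonyl)amino on a saturated chain carbon, two bonds along the chain from a nitrogen on an aromatic ring. In this assay compound 1 gives 0%, so that the step of no change at the digits printed from compound 3 to compound 1 (within the scatter). Compound 2 `CN(CCCCN(C)c1ncnc2c1ncn2[C@@H]1O[C@H](COP(=O)(O)OP(=O)(O)OP(=O)(O)O)[C@@H](O)[C@H]1O)C(=O)CCCNC(=O)CI` gives 0% in this assay, level with compounds 1 and 3 at the digits reported; the difference between the core of compound 2 and the core of compound 3 is not broken down here.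

Compound 4 `CN(CCCCN(C)c1ncnc2c1ncn2[C@@H]1O[C@H](COP(=O)(O)OP(=O)(O)OP(=O)(O)O)[C@@H](O)[C@H]1O)C(=O)CCCCCNC(=O)CI` has not yet been measured. It differs from compound 2 by 2-(((iodomethyl)carbonyl)amino)ethyl in place of ((iodomethyl)carbonyl)amino on a saturated chain carbon, three bonds along the chain from a carbonyl carbon. This is the same kind of change as that from compound 3 to compound 1, but the place is not the same: in the earlier pair the saturated chain carbon lies two bonds along the chain from a nitrogen on an aromatic ring, whereas here it lies three bonds along the chain from a carbonyl carbon. The step is expected to be no change at the digits printed from compound 2 to compound 4 (within the scatter). That expectation rests on the earlier step of no change at the digits printed from compound 3 to compound 1 (within the scatter) and on compound 2 standing at 0%. Compound 4 is therefore estimated at 0% in this assay, with a range from -8% to 10%.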

Compound 4, a percentage reported as inhibition, at one concentration (the size of the read-out at that concentration, not a potency): 0%
The estimate for compound 4 equals the measured number at the digits printed; low and high end bracket the measured number.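

In this assay, 2-(((iodomethyl)carbonyl)amino)ethyl in place of ((iodomethyl)carbonyl)amino gives no change at the digits printed from compound 2 to compound 4 (within the scatter), and set beside the earlier step on the other core, the result is the same: the same change on two cores in this assay, no change at the digits printed (within the scatter) from compound 3 to compound 1 and no change at the digits printed (within the scatter) from compound 2 to compound 4, 0 percentage points apart, within the scatter of two such steps. In these two pairs, then, the change carries from one core to the other without a difference, even though its place on the chain is not the same. This does not show that the change is neutral in general, since all four compounds read alike, with compound 4 at 0%, and the agreement says nothing about how the change would carry on a core that shows measurable inhibition.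

From the compounds shown here alone, whether a longer chain than that of compound 4, or an acrylamide in place of the iodoacetamide end, would give any reading in this assay stays open. So does whether the same change would read alike on a third core.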